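A few compounds are considered here, and "the series" means these few. Any claim that something is new, unique, unknown or untested is made for them only; others in the source may bear on it.

Series notes, an assay on LM cells for displacement of a labelled ligand from Neuropeptide Y receptor type 5 (Homo sapiens); a lower number here means a stronger inhibitor, a higher number a weaker inhibitor.

For the measured compounds named here, compound 1 `Fc1ccc(C2(c3ccc(F)cc3)CNC(c3cccc(F)c3)=N2)cc1` gives 10 nM in this assay; it stands second highest of the three numbers measured so far. Compound 2 `N#Cc1cccc(C2=NC(c3ccc(F)cc3)(c3ccc(F)cc3)CN2)c1` gives 2.7 nM, and compound 3 `OCc1cccc(C2=NC(c3ccc(F)cc3)(c3ccc(F)cc3)CN2)c1` gives 59 nM. The two measured steps from compound 1 run in opposite directions: a 3.7-fold lower number from compound 1 to compound 2 (0.57 log units; beyond the scatter), while a 5.9-fold higher number from compound 1 to compound 3 (0.77 log units; beyond the scatter). Between the two substituted analogues a 22-fold higher number from compound 2 to compound 3 (1.34 log units; beyond the scatter).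

Compound 4 `Fc1ccc(C2(c3ccc(F)cc3)CNC(c3ccncc3)=N2)cc1` has not yet been measured. It differs from compound 1 by pyridin-4-yl in place of 3-fluorophenyl on a carbon with a double bond to nitrogen. Going by the values given here, no measured step changes this ring itself; the steps from compound 1 to compound 2 and from compound 1 to compound 3 only swap a substituent on the 3-fluorophenyl that leaves here, so they bear on the change indirectly at most. They show that alterations at this part of the core of compound 1 move the number by modest amounts in either direction, and a step of similar size, more likely toward a higher number than a lower one, is expected in this assay. The estimate for compound 4 is 20 nM, within 5 nM to 80 nM. This corresponds to an expected 2.0-fold higher number from compound 1 to compound 4 (0.30 log units; within the scatter).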

Compound 4, half-maximal inhibitory concentration: 160 nM
Compound 4: the middle estimate sits 8.0-fold (0.90 log units) below what was measured; the whole stated range lies below it.
By their numbers in this assay, from the lowest: compound 2; then compound 1; then compound 3; then compound 4.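

In this assay, exchanging the whole aromatic ring on the carbon with a double bond to nitrogen moves the number further than either substituent swap from compound 1 (a 16-fold higher number from compound 1 to compound 4 (1.20 log units; beyond the scatter)). Compound 4 also lies above both other analogues (a 2.7-fold higher number from compound 3 to compound 4 (0.43 log units; beyond the scatter); a 59-fold higher number from compound 2 to compound 4 (1.77 log units; beyond the scatter)), which makes pyridin-4-yl the least favourable of the four groups shown at this position. Nothing available here bears on why the number rises so far with this change.

The step changes the ring atom and removes the 3-substituent together, so the two contributions cannot be separated. A plain phenyl and a pyridin-3-yl on the same carbon would show which of them carries the rise, and whether the position of the ring nitrogen matters.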